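Swapping cyclopropyl for 2-chlorophenyl on the shared core

This account rests on a few compounds, and the source may have more. Where it says the series, first, only, none or still open, it means among the compounds named here.

Compound 1 `O=S(=O)(Nc1ccc(F)c(C#Cc2cnc3[nH]ncc3c2)c1F)c1cccnc1`: in a functional assay on HCT-116 cells (Homo sapiens) for antiproliferative activity, read by MTT assay, with a stated time of 68 h (on this read-out higher numbers stand for weaker inhibition and lower numbers for stronger inhibition), compound 1 reaches only a limit, > 10000 nM.
Compound 2 `O=S(=O)(Nc1ccc(F)c(C#Cc2cnc3[nH]nc(C4CC4)c3c2)c1F)c1cccnc1`: in this assay compound 2 gives 584 nM.

Compound 2 holds the only number shown; the other value is a limit, (the limit of > 10000 nM in this assay, at which 1 of the 2 values shown sits). Within the data shown here, the one measured step, an at least 17-fold lower number from compound 1 to compound 2 (1.23 log units; beyond the scatter), came with cyclopropyl in place of hydrogen on an aromatic carbon. Compound 3 `O=S(=O)(Nc1ccc(F)c(C#Cc2cnc3[nH]nc(-c4ccccc4Cl)c3c2)c1F)c1cccnc1` differs from compound 2 by 2-chlorophenyl in place of cyclopropyl on an aromatic carbon. The measured step shows that a group on this carbon changes the number strongly, but it does not tell how a larger aromatic group would fare. A modest step is expected, a 1.7-fold lower number from compound 2 to compound 3 (0.22 log units; within the scatter). Compound 3 is estimated at 350 nM, between 70 nM and 2500 nM.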

Compound 3, half-maximal inhibitory concentration: > 10000 nM
Compound 3: only a limit was reported (the forecaster's own chance of this, stated with the estimate: 5%); middle value at least 28-fold (1.45 log units) away from the limit.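

Not every group on this carbon lowers the number: 2-chlorophenyl in place of cyclopropyl gave an at least 17-fold higher number from compound 2 to compound 3 (1.23 log units; beyond the scatter) in this assay, so among the groups shown only cyclopropyl improves on hydrogen. The reading for compound 3 is a limit, not a number: the limit of > 10000 nM in this assay, at which 2 of the 3 values shown sit. The step from compound 1 to compound 3 cannot be read.

Whether the six-membered aromatic ring itself or its chlorine accounts for this step remains open. So does how a plain phenyl, a methyl or an amine on this carbon would read.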